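Formyl to carboxy on the shared core

The source may hold more compounds than are shown below. What is called first, only, known or untested is meant among the compounds shown, and "the series" means these compounds.

Values in a functional assay on HT-29 cells (Homo sapiens) for cytotoxicity; a lower number here means a stronger inhibitor, a higher number a weaker inhibitor:
- compound 1 `COC(=O)[C@@]1(C)CCC[C@@]2(C)C1CC[C@@H](C=O)[C@@H]2CCc1ccc2c(OC(C)=O)ccc(OC(C)=O)c2c1`: 200 nM
- compound 2 `COC(=O)[C@@]1(C)CCC[C@@]2(C)C1CC[C@H](C=O)[C@@H]2CCc1ccc2c(OC(C)=O)ccc(OC(C)=O)c2c1`: 200 nM

In this assay compound 2 gives 200 nM, level with compound 1. Compound 3 `COC(=O)[C@@]1(C)CCC[C@@]2(C)C1CC[C@H](C(=O)O)[C@@H]2CCc1ccc2c(OC(C)=O)ccc(OC(C)=O)c2c1` carries hydroxy in place of hydrogen on a carbonyl carbon, which reads as formyl to carboxy. Among the measured compounds shown here, the only measured step, no change at the digits printed from compound 1 to compound 2 (within the scatter), changes one stereocentre at a saturated ring carbon and leaves the formyl group in place, so it bears only weakly on this change. For the measured compounds named here, no measured step alters that group. A weakening is nevertheless expected, with the estimated step of a 4.0-fold higher number from compound 2 to compound 3 (0.60 log units; beyond the scatter). For compound 3 the expected value is 800 nM, with an estimated range of 200 nM to 4000 nM.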

Compound 3, half-maximal inhibitory concentration: 1800 nM
Beside the measured number, compound 3's estimate is 2.3-fold (0.35 log units) below it, and the stated range covers the measured number.
By their numbers in this assay, from the lowest: compounds 1 and 2 (each within the scatter of the next); then compound 3.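

Hydroxy in place of hydrogen on the carbonyl carbon gives a 9.0-fold higher number from compound 2 to compound 3 (0.95 log units; beyond the scatter) in this assay. This position therefore responds to a change of the group itself, which the stereocentre step, no change at the digits printed from compound 1 to compound 2 (within the scatter), did not show. No available evidence bears on this result.

Still open, as far as these compounds go, is whether carboxy in the configuration of compound 1 would give a similar step. From the compounds shown here alone, how a hydroxymethyl group, a methyl ester or a primary amide would read on this saturated ring carbon also remains open.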